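The source may report more compounds than this note shows. Statements on the series, on what has been measured and on what is new or still open speak of the compounds shown alone.

Compounds measured in a physicochemical assay for lipophilicity, read by HPLC, at pH 3.0; a lower number here means a more polar compound, a higher number a more lipophilic compound:
- compound 1 `CN(C)Cc1csc(NC(=O)c2cc(C(C)(C)C)nn2Cc2ccccc2)n1`: 2.6
- compound 2 `CC(C)(C)c1cc(C(=O)Nc2ccccn2)n(Cc2ccccc2)n1`: 4.5
- compound 3 `Cn1nc(C(C)(C)C)cc1C(=O)Nc1nc(CN)cs1`: 1.2

Compound 2 stands highest of these three at 4.5. Compound 1 is the nearest to it at 2.6, and compound 3 is the furthest at 1.2.

The next compound, compound 4 `CC(C)(C)c1cc(C(=O)Nc2ccncc2)n(Cc2ccccc2)n1`, differs from compound 2 in one place: pyridin-4-yl in place of pyridin-2-yl on an amide-type nitrogen. In words, pyridin-4-yl stands in place of pyridin-2-yl on an amide-type nitrogen. The two compounds have the same atoms, joined differently.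

Within the data shown here, only one measured step touches this place: a number 1.90 log units higher from compound 1 to compound 2 (beyond the scatter). That step is large, but it brings in a very different group. It shows that a change here can move the number a long way, yet it does not show what an exchange between pyridin-2-yl and pyridin-4-yl does. Among the measured compounds shown here, no measured pair tests that exchange directly, so the size is a judgement. A somewhat smaller step than the measured one is expected, and a downward direction is expected with compound 2 at the top of the series at 4.5.

The estimated change is a number 1.40 log units lower from compound 2 to compound 4 (beyond the scatter). Compound 4 is therefore expected at 3.1, with an estimated range of 2.3 to 4.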

Compound 4, distribution coefficient: 2.6
Estimate against measurement, compound 4: 0.50 log units above; measured number inside the range.
By their numbers in this assay, from the lowest: compound 3; then compounds 1 and 4 (each within the scatter of the next); then compound 2.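

In this assay, exchanging pyridin-2-yl for pyridin-4-yl on the amide-type nitrogen gives a number 1.90 log units lower from compound 2 to compound 4 (beyond the scatter) even though the two groups have the same heavy atoms, the same count of hydrogen-bond acceptors and no net charge. The earlier compounds shown here showed that this position could move the number when a quite different group entered, as in a number 1.90 log units higher from compound 1 to compound 2 (beyond the scatter) but this new step is the same size and comes from rearranging the same atoms, so how the pyridine is joined matters here as much as that larger change of group. Pyridin-4-yl and 4-((dimethylamino)methyl)-1,3-thiazol-2-yl, though very different in make-up, cannot be told apart in this assay on this core, with no change at the digits printed from compound 1 to compound 4 (within the scatter) and nothing shown here gives a measured reason for either step.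

Where pyridin-3-yl or a plain phenyl on the amide-type nitrogen would fall relative to these compounds remains open. On these data alone, it is also open whether the exchange from pyridin-2-yl to pyridin-4-yl gives a step of similar size on the core of compound 3, which carries methyl in place of benzyl.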